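The source may report more compounds than this note shows. Statements on the series, on what has been measured and on what is new or still open speak of the compounds shown alone.

Going by the values given here, in a functional assay on LOX IMVI cells (Homo sapiens) for inhibition, read by sulforhodamine B assay, with a stated time of 48 h (a higher number here means a weaker inhibitor of growth, a lower number a stronger inhibitor of growth), compound 2 `NC(=O)c1cc(Br)ccc1NC(=O)/C=C/c1ccccc1` gives 3270 nM, the lowest of the two numbers so far, while compound 1 `Cc1ccc(NC(=O)/C=C/c2ccccc2)c(C(N)=O)c1` gives 7650 nM. Compound 3 `NC(=O)c1cc(I)ccc1NC(=O)/C=C/c1ccccc1` follows from compound 2 by one change: iodo in place of bromo on an aromatic carbon. Among the compounds with values here, the one measured step bearing on this is a 2.3-fold lower number from compound 1 to compound 2 (0.37 log units; beyond the scatter), modest and beyond the scatter, with bromo in place of methyl on that carbon. On that single step, only a slight lean to a lower number is expected in this assay, with nothing beyond the scatter. The estimated step is a 1.3-fold lower number from compound 2 to compound 3 (0.12 log units; within the scatter). For compound 3 the estimate is 2500 nM, with an expected range from 1200 nM to 5000 nM.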

Compound 3, concentration for 50% growth inhibition: 3750 nM
Estimate against measurement, compound 3: 1.5-fold (0.18 log units) below; the measured number falls inside the stated range.
By their numbers in this assay, from the lowest: compounds 2 and 3 (each within the scatter of the next); then compound 1.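

At the carbon para to a large group, iodo in place of bromo gives a 1.1-fold higher number from compound 2 to compound 3 (0.06 log units; within the scatter) in this assay, so this assay does not separate the two halogens. Iodo in place of methyl gives a 2.0-fold lower number from compound 1 to compound 3 (0.31 log units; beyond the scatter), so the step away from methyl, first seen with bromo, also appears with iodo. No evidence bearing on the cause is available. From the compounds shown here alone, how an amine, a carboxylic acid or a longer chain at this carbon would read remains open. So does whether this halogen result holds elsewhere on the shared core.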